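This account rests on a few compounds, and the source may have more. Where it says the series, first, only, none or still open, it means among the compounds named here.

Measured in a functional assay on blood (Homo sapiens), with a stated time of 60 min, in the presence of a further agent that is not named here; on this read-out lower numbers stand for an effect already at smaller amounts and higher numbers for an effect only at larger amounts of compound:

- Compound 1 `O=C(Nc1nccs1)C1(S(=O)(=O)c2ccc(Oc3ccc(OC(F)(F)F)cc3)cc2)CCC2(CCNCC2)C1`: > 15000 nM
- Compound 2 `Nc1ccc(-c2ccccc2)cc1NC(=O)C1(S(=O)(=O)c2ccc(Oc3ccc(OC(F)(F)F)cc3)cc2)CCC2(CCNCC2)C1`: <= 400 nM

Both results are limits of the assay and not exact numbers, so the gap between the two compounds cannot be sized. In this assay, compound 2 stands at <= 400 nM, and this value is a limit. Its true position could therefore lie anywhere on the side that the limit allows.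

Compound 3 `Nc1ccc(F)cc1NC(=O)C1(S(=O)(=O)c2ccc(Oc3ccc(OC(F)(F)F)cc3)cc2)CCC2(CCNCC2)C1` keeps the shared core of compound 2 and carries one change, fluoro in place of phenyl on an aromatic carbon, para to an amino group. For the measured compounds named here, no measured pair of compounds differing in one place is available to size such a change. The expectation is therefore a matter of judgement: a moderate move toward higher numbers in this assay, probably beyond the scatter, though no move at all cannot be ruled out. The expected change is an at least 1.7-fold higher number from compound 2 to compound 3 (0.24 log units; that floor lies within the scatter). For compound 3, the estimated value is 700 nM, with an expected range from 150 nM to 4000 nM.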

Compound 3, half-maximal effective concentration: > 15000 nM
Compound 3 ended at the assay's limit; the forecaster's own chance of this, stated with the estimate: 30%; middle value at least 21-fold (1.33 log units) from the limit.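

In this assay, fluoro in place of phenyl on this aromatic carbon, para to an amino group, gives an at least 37-fold higher number from compound 2 to compound 3 (1.57 log units; beyond the scatter), so the first pair differing in one place shows that the read-out depends strongly on what sits at this position. Compound 3 ends at a limit of the assay, the same one as compound 1, so fluoro at this place leaves no measurable effect within the range tested, even with the 2-amino-5-fluorophenyl group on the amide-type nitrogen in place of 1,3-thiazol-2-yl: the limit of > 15000 nM in this assay, at which 2 of the 3 values shown sit. Compound 2 alone stands at the opposite limit, which makes the phenyl group the only feature here that separates a compound from that upper limit: the limit of <= 400 nM in this assay, at which 1 of the 3 values shown sits.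

Going by these compounds, the true size of the step remains open, as both of its ends are limits, and the step from compound 1 to compound 3 cannot be read at all. The compounds shown also leave open whether a methyl, a methoxy or a pyridyl group at this place would stay with compound 2 or fall with compound 3.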